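The source may hold more compounds than are shown below. What is called first, only, known or untested is meant among the compounds shown, and "the series" means these compounds.

Going by the values given here, in an ADME assay on L1210/0 cells (Mus musculus) for cytotoxicity, with a stated time of 48 h (a lower number here means a stronger inhibitor, a higher number a weaker inhibitor), compound 1, of structure `N#CSc1cn([C@H]2C[C@H](O)[C@@H](CO)O2)c(=O)[nH]c1=O`, gives 78900 nM, the only plain number in this set. Compound 2, of structure `Nc1nc(Cl)c2ncn([C@H]3CCCC[C@H]3CO)c2n1`, reaches only a limit of the assay, > 200000 nM, as noted in the limit of > 200000 nM in this assay, at which 1 of the 2 values shown sits. Compound 3, of structure `C=CC#Cc1cn([C@H]2C[C@H](O)[C@@H](CO)O2)c(=O)[nH]c1=O`, awaits measurement. The change is a group of 4 heavy atoms (4 carbon; no ring) in place of a group of 3 heavy atoms (1 carbon, 1 nitrogen, 1 sulfur; no ring), on an aromatic carbon. Among the compounds with values here, no measured step is available here, so the expectation for compound 3 rests on compound 1 alone. The expected step of a 1.3-fold lower number from compound 1 to compound 3 (0.12 log units; within the scatter) is estimated to stay within the usual scatter, with no direction favoured. Compound 3 is thus expected to give about 60000 nM, estimated between 12000 nM and 200000 nM.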

Compound 3, half-maximal inhibitory concentration: > 200000 nM
Compound 3: only a limit was reported; the forecaster's own chance of this, stated with the estimate: 25%; middle value at least 3.3-fold (0.52 log units) from the limit.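

At this aromatic carbon, placing the group of 4 carbon where cyanosulfanyl stood gives an at least 2.5-fold higher number from compound 1 to compound 3 (0.40 log units; beyond the scatter) in this assay, the first sign that this read-out responds to what sits at this position. For compound 3, > 200000 nM is a limit of the assay and not a number. The step therefore has a known minimum but no known size, and values in this set gather at that limit: the limit of > 200000 nM in this assay, at which 2 of the 3 values shown sit.

The compounds shown leave open whether any group at this position gives a lower number than compound 1. An amine, a bromine atom or a longer alkyl chain here would help to settle this.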